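Methyl on the Phenol Oxygen: What to Expect in Cells

The source may hold more compounds than are shown below. What is called first, only, known or untested is meant among the compounds shown, and "the series" means these compounds.

Compound 1 `COc1cc(Cl)cc(-c2nn(-c3cccc(NC(=O)c4ccc(Cl)c(Cl)c4)c3)cc2-c2ccncc2)c1`: 46.4%
Compound 2 `O=C(Nc1cccc(-n2cc(-c3ccncc3)c(-c3cc(O)cc(Cl)c3)n2)c1)Nc1ccc(Cl)c(C(F)(F)F)c1`: 5.24%

In a functional assay on K562 cells (Homo sapiens) for inhibition, read by sulforhodamine B assay, with a stated time of 48 h, tested at 10 uM (on this read-out higher numbers stand for a weaker effect at the one concentration tested and lower numbers for a stronger effect), compound 2 gives 5.24%, the lower of the two measured numbers and so the stronger effect; compound 1 gives 46.4%, and the gap between them lies beyond the usual scatter. Compound 3 `COc1cc(Cl)cc(-c2nn(-c3cccc(NC(=O)Nc4ccc(Cl)c(C(F)(F)F)c4)c3)cc2-c2ccncc2)c1` is not yet measured. It differs from compound 2 by methyl in place of hydrogen on an oxygen on an aromatic ring. Within the data shown here, no pair of measured compounds shows this change on its own, so its size is uncertain; in this assay a modest rise, meaning a somewhat weaker effect, is expected. Compound 3 is expected to give 15%, within 3% to 45%, an expected step of a number 9.8 percentage points higher from compound 2 to compound 3 (within the scatter).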

Compound 3, a percentage reported as activity, at one concentration (the size of the read-out at that concentration, not a potency): 8.93%
Compound 3: middle estimate off by 6.1 percentage points, on the high side; the range from low to high includes it.
By their numbers in this assay, from the lowest: compounds 2 and 3 (each within the scatter of the next); then compound 1.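

In this assay, going from hydroxy to methoxy gives a number 3.7 percentage points higher from compound 2 to compound 3 (within the scatter), so the hydrogen on this oxygen is not required for a strong effect at this one concentration. With methoxy kept, (4-chloro-3-(trifluoromethyl)phenyl)amino in place of 3,4-dichlorophenyl on the carbonyl carbon gives a number 37.5 percentage points lower from compound 1 to compound 3 (beyond the scatter), a far larger step. No measurement here explains either result. On these data alone, whether an ethyl group on this oxygen, or an amine in place of the hydroxy, would keep the effect remains open. As far as these compounds go, whether compound 2 and compound 3 would differ in effect at other concentrations also remains open; the data cover only this one concentration.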